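Cyano for Fluoro: What to Expect of Compound 4

The source may hold more compounds than are shown below. What is called first, only, known or untested is meant among the compounds shown, and "the series" means these compounds.

Of the compounds shown here, three that share one core have been measured in a functional assay on HEK293 cells for negative allosteric modulation of metabotropic glutamate receptor 5 (Homo sapiens), read by calcium flux, with a stated time of 20 min; a higher number here means a weaker inhibitor, a lower number a stronger inhibitor. Among the compounds with values here, compound 1 `Cc1ccnc(-c2cc3n(n2)CCN(C(=O)c2ccccc2)C3)c1` gives 451 nM, and compound 2 `Cc1ccc(-c2cc3n(n2)CCN(C(=O)c2ccccc2)C3)nc1` gives 244 nM; the single recorded step between them is a 1.8-fold lower number from compound 1 to compound 2 (0.27 log units; within the scatter). Compound 3 `O=C(c1cccc(F)c1)N1CCn2nc(-c3ccc(F)cn3)cc2C1` gives 257 nM, the second highest of the three numbers; compound 2 is its nearest neighbour and compound 1 its furthest, and both gaps lie within the scatter, so no order among the three can be claimed.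

Compound 4 `N#Cc1cccc(C(=O)N2CCn3nc(-c4ccc(F)cn4)cc3C2)c1` differs from compound 3 by cyano in place of fluoro on an aromatic carbon. Within the data shown here, no measured step concerns this part of the structure: the only step available, the one from compound 1 to compound 2, concerns a different group and is itself within the scatter. The measured compounds therefore give no direct guidance on how this assay responds to this exchange, and the expectation has to rest on the narrow spread of the three numbers seen so far.

On that basis compound 4 is expected to stay close to compound 3, with an estimated step of a 1.3-fold lower number from compound 3 to compound 4 (0.11 log units; within the scatter), that is, none beyond the scatter. The estimate for compound 4 in this assay is 200 nM, within a range from 60 nM to 700 nM.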

Compound 4, half-maximal inhibitory concentration: > 10000 nM
Compound 4: a limit, no number; the forecaster's own chance of this, stated with the estimate: 3%; at least 50-fold (1.69 log units) between middle value and limit.
By their numbers in this assay, from the lowest: compounds 2, 3 and 1 (each within the scatter of the next). At a limit, above all of these: compound 4.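

In this assay, within the data shown here, the change from 3-fluorophenyl to 3-cyanophenyl gives an at least 38-fold higher number from compound 3 to compound 4 (1.59 log units; beyond the scatter), the first step here to lie beyond the scatter, and it shows that this place on the six-membered aromatic ring of carbon only, meta to a large group, does not tolerate every small group. Among these compounds, the only earlier step, a 1.8-fold lower number from compound 1 to compound 2 (0.27 log units; within the scatter), concerned another part of the structure and lay within the scatter, so the narrow spread of the first three compounds said nothing about this position. The value of compound 4 is a limit and not a number, so the step has a lower bound but no known full size: the limit of > 10000 nM in this assay, at which 1 of the 4 values shown sits.

The compounds shown leave open whether this sharp response belongs to cyano alone or would also appear with other groups at this place, such as chlorine, methoxy, an amine or a carboxylic acid. They also leave open whether a cyano group at another place on this ring, or the same exchange on a compound with a different group on the other side of the core, would give a step of similar size.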